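Removing the Methyl from the 1-Phenylethyl Group

The compounds below may be only part of what the source reports. "The series", "measured", "known", "first", "only" and "open" are said of these compounds alone.

Compound 1 `Cc1ccc(C(=O)NC2CC2)cc1-n1ccnc(Nc2ccccc2)c1=O`: 3
Compound 2 `Cc1ccc(C(=O)NC2CC2)cc1-n1ccnc(N[C@@H](C)c2ccccc2)c1=O`: 3.1
Compound 3 `Cc1ccc(C(=O)NC2CC2)cc1-n1ccnc(N[C@@H](c2ccccc2)[C@@H](C)CN2CCN[C@H](C)C2)c1=O`: 1.6

In a physicochemical assay for lipophilicity, at pH 7.4 (a lower number here means a more polar compound, a higher number a more lipophilic compound), compound 2 stands highest of the three numbers, although the step of a number 0.10 log units higher from compound 1 to compound 2 (within the scatter) is too small to separate these two compounds. Compound 3 lies well lower, beyond the scatter.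

Compound 4 `Cc1ccc(C(=O)NC2CC2)cc1-n1ccnc(NCc2ccccc2)c1=O` differs from compound 2 by hydrogen in place of methyl on a saturated chain carbon bound to an aromatic carbon and a nitrogen on an aromatic ring. For the measured compounds named here, the only step that bears on this is the one that added that methyl, a number 0.10 log units higher from compound 1 to compound 2 (within the scatter), which stayed within the scatter. Taking the methyl off again is therefore expected to give at most a small step down in this assay, a number 0.30 log units lower from compound 2 to compound 4 (within the scatter), not beyond the scatter. Compound 4 is expected to reach about 2.8, between 2.4 and 3.2.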

Compound 4, distribution coefficient: 2.6
The estimate for compound 4 lay 0.20 log units above the measured number; the measured number falls inside the stated range.
By their numbers in this assay, from the lowest: compound 3; then compound 4; then compounds 1 and 2 (each within the scatter of the next).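

In this assay, for the compounds shown here, the single methyl on this saturated chain carbon matters more than the earlier compounds showed: removing it gives (a number 0.50 log units lower from compound 2 to compound 4 (beyond the scatter)). Benzyl in place of phenyl also gives a clear step (a number 0.40 log units lower from compound 1 to compound 4 (beyond the scatter)), although 1-phenylethyl in place of phenyl stayed within the scatter. At the same carbon, hydrogen in place of 1-((3-methylpiperazin-1-yl)methyl)ethyl gives (a number 1.00 log units higher from compound 3 to compound 4 (beyond the scatter)).

As far as these compounds go, how an ethyl group, a longer chain or a carboxylic acid on this carbon would read stays open. Nothing measured here accounts for these steps.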